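Trading a methyl for a chlorine on the outer phenyl ring

A few compounds are considered here, and "the series" means these few. Any claim that something is new, unique, unknown or untested is made for them only; others in the source may bear on it.

Compound 1, `O=c1[nH]cc(S(=O)(=O)Nc2cccc(-c3cn(-c4ccccc4F)nn3)c2)c(=O)[nH]1`, in a functional assay on A549 cells (Homo sapiens) for antiproliferative activity, read by MTT assay, with a stated time of 24 h (on this read-out higher numbers stand for weaker inhibition and lower numbers for stronger inhibition), gives > 20000 nM, a limit of the assay rather than a number.
Compound 2, `Cc1ccccc1-n1cc(-c2ccc(NS(=O)(=O)c3c[nH]c(=O)[nH]c3=O)cc2)nn1`, in this assay gives 3130 nM.

Of the compounds shown here, two sharing the same core have been measured. Going by the values given here, compound 2 is the only one with a true number, while compound 1 stands at the limit, the point described by the limit of > 20000 nM in this assay, at which 1 of the 2 values shown sits. Among the compounds with values here, no single-change step between measured compounds is available, so the step to compound 3, `O=c1[nH]cc(S(=O)(=O)Nc2ccc(-c3cn(-c4cccc(Cl)c4)nn3)cc2)c(=O)[nH]1`, has no direct precedent. The change is 3-chlorophenyl in place of 2-methylphenyl on an aromatic nitrogen, a swap of one seven-heavy-atom aromatic ring for another of the same size and neither adding nor removing any donor or acceptor. With nothing measured to anchor this exchange, the expected step of a 1.1-fold higher number from compound 2 to compound 3 (0.05 log units; within the scatter) is none beyond the usual scatter. Compound 3 is therefore estimated at 3500 nM, with a likely range from 1000 nM to 12000 nM.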

Compound 3, half-maximal inhibitory concentration: 2310 nM
Estimate against measurement, compound 3: 1.5-fold (0.18 log units) above, and the stated range covers the measured number.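

In this assay, going by these compounds alone, replacing 2-methylphenyl with 3-chlorophenyl on an aromatic nitrogen gives the first step that can be read between two measured compounds, a 1.4-fold lower number from compound 2 to compound 3 (0.13 log units; within the scatter), so compound 2 and compound 3 cannot be told apart on this read-out. Two things differ at once here, the identity of the small group on the outer ring and where it sits on that ring, yet the two numbers stay within the usual scatter of each other. Compound 1 still offers no number for comparison, only a limit: the limit of > 20000 nM in this assay, at which 1 of the 3 values shown sits.

The two features of this swap remain tangled, and 2-chlorophenyl or 3-methylphenyl would be needed to pull them apart. Also open, going by these compounds, is whether a plain phenyl, a cyclohexyl ring or a chain ending in an amine on this nitrogen would move the number beyond the scatter.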